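This account rests on a few compounds, and the source may have more. Where it says the series, first, only, none or still open, it means among the compounds named here.

Measured compounds:
compound 1, `Clc1ccccc1-c1cc(-c2cnn(C3CCNCC3)c2)on1`, 120 nM
compound 2, `Fc1ccc(Cl)c(-c2cc(-c3cnn(C4CCNCC4)c3)on2)c1`, 270 nM
compound 3, `Fc1ccc(-c2cc(-c3cnn(C4CCNCC4)c3)on2)c(Cl)c1`, 220 nM

All three share a core and differ only in the aryl group attached to it. In an assay on isolated protein for positive allosteric modulation of Neuronal acetylcholine receptor; alpha4/beta2 (Homo sapiens) (a higher number here means that more compound is needed for the effect, a lower number that less compound is needed), compound 3 gives 220 nM, which stands second highest of the three numbers; the nearest is compound 2, a 1.2-fold lower number from compound 2 to compound 3 (0.09 log units; within the scatter), and the furthest is compound 1, a 1.8-fold higher number from compound 1 to compound 3 (0.26 log units; within the scatter), so compound 3 sits within the scatter of both neighbours.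

Compound 4, `Clc1cnccc1-c1cc(-c2cnn(C3CCNCC3)c2)on1`, has not yet been measured in this assay. It differs from compound 3 by 3-chloropyridin-4-yl in place of 2-chloro-4-fluorophenyl on an aromatic carbon. For the measured compounds named here, no measured step covers an exchange of the carbon ring for a ring with one hetero atom; the steps that come closest concern only the fluorine, which entered with a 2.3-fold higher number from compound 1 to compound 2 (0.35 log units; beyond the scatter) and a 1.8-fold higher number from compound 1 to compound 3 (0.26 log units; within the scatter), both small. Going by the values given here, since the fluorine leaves again in compound 4, and since nothing among the measured compounds speaks to the ring nitrogen, compound 4 is expected to stay close to compound 3, with a 1.1-fold higher number from compound 3 to compound 4 (0.06 log units; within the scatter) as the estimated step. In this assay compound 4 is estimated at 250 nM, with a plausible range from 80 nM to 800 nM.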

Compound 4, half-maximal effective concentration: 200 nM
The estimate for compound 4 lay 1.3-fold (0.10 log units) above the measured number; the measured number falls inside the stated range.
By their numbers in this assay, from the lowest: compounds 1, 4, 3 and 2 (each within the scatter of the next, the first and the last beyond it).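

In this assay, the exchange of 2-chloro-4-fluorophenyl for 3-chloropyridin-4-yl gives a 1.1-fold lower number from compound 3 to compound 4 (0.04 log units; within the scatter), so a ring with 1 hetero atom in this place, on an aromatic carbon of the five-membered ring, leaves the number within the scatter of the fluorinated compound, and the same holds for the other fluorinated aryl group with a 1.4-fold lower number from compound 2 to compound 4 (0.13 log units; within the scatter). The cleanest reading of the ring nitrogen comes from the comparison without fluorine, a 1.7-fold higher number from compound 1 to compound 4 (0.22 log units; within the scatter), where the aryl group differs from 2-chlorophenyl by that nitrogen alone and the step again stays within the scatter. Nothing available explains why the number holds through this exchange.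

From the compounds shown here alone, all four compounds carry a chlorine on the aryl ring, so it remains open whether a methyl, a methoxy or a nitrile could stand in its place with a similar number. Also open is how an amino group or a carboxylic acid on the 3-chloropyridin-4-yl ring would read in this assay, since the compounds shown cover only hydrogen and fluoro as further substituents on the aryl group.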